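Swapping an indole for a ring with an extra nitrogen

A few compounds are considered here, and "the series" means these few. Any claim that something is new, unique, unknown or untested is made for them only; others in the source may bear on it.

Of the compounds shown here, three built on one shared core have been tested in a functional assay on DU-145 cells (Homo sapiens) for inhibition, read by trypan blue exclusion, with a stated time of 72 h; a higher number here means a weaker inhibitor, a lower number a stronger inhibitor. Compound 1, `Cn1c(=O)c(S(=O)(=O)c2ccc(F)cc2F)cc2cnc(Nc3cccc4[nH]ccc34)nc21`, gives 750 nM. Compound 2, `Cn1c(=O)c(S(=O)(=O)c2ccc(F)cc2F)cc2cnc(Nc3cnc4[nH]ccc4c3)nc21`, gives 750 nM. Compound 3, `Cn1c(=O)c(S(=O)(=O)c2ccc(F)cc2)cc2cnc(Nc3cccc4[nH]ccc34)nc21`, gives 750 nM. All three values sit level with one another.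

Compound 1 and compound 2 differ in a single place: a group of 9 heavy atoms (7 carbon, 2 nitrogen; one five-membered aromatic ring with 1 hetero atom, one six-membered aromatic ring with 1 hetero atom) in place of a group of 9 heavy atoms (8 carbon, 1 nitrogen; one five-membered aromatic ring with 1 hetero atom, one six-membered aromatic ring of carbon only), on a nitrogen on an aromatic ring. This change made a step of no change at the digits printed from compound 1 to compound 2 (within the scatter).

The cores of compound 1 and compound 3 differ in another single place: hydrogen in place of fluoro on an aromatic carbon. That change made a step of no change at the digits printed from compound 1 to compound 3 (within the scatter).

Compound 4, `Cn1c(=O)c(S(=O)(=O)c2ccc(F)cc2)cc2cnc(Nc3cnc4[nH]ccc4c3)nc21`, has not yet been measured. It differs from compound 3 in this way: a group of 9 heavy atoms (7 carbon, 2 nitrogen; one five-membered aromatic ring with 1 hetero atom, one six-membered aromatic ring with 1 hetero atom) in place of a group of 9 heavy atoms (8 carbon, 1 nitrogen; one five-membered aromatic ring with 1 hetero atom, one six-membered aromatic ring of carbon only), on a nitrogen on an aromatic ring. The place of this change is, word for word, the same as in the change from compound 1 to compound 2, so it is the same change, now made on the core of compound 3 rather than the core of compound 1.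

The expectation for compound 4 rests on the earlier step, which was no change at the digits printed from compound 1 to compound 2 (within the scatter). It also rests on the starting point: compound 3 gives 750 nM, level with compound 1. The expected step is therefore no change at the digits printed from compound 3 to compound 4 (within the scatter). Compound 4 is estimated at 750 nM, with an expected range from 400 nM to 1400 nM.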

Compound 4, half-maximal inhibitory concentration: 500 nM
Estimate against measurement, compound 4: 1.5-fold (0.18 log units) above; low and high end bracket the measured number.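

In this assay, among the compounds shown here, placing the group with the extra ring nitrogen where the 1H-indol-4-yl group stood gives a 1.5-fold lower number from compound 3 to compound 4 (0.18 log units; within the scatter), and this agrees with the same change on the other core: the same change on two cores in this assay, no change at the digits printed (within the scatter) from compound 1 to compound 2 and a 1.5-fold lower number (0.18 log units; within the scatter) from compound 3 to compound 4, 1.5-fold (0.18 log units) apart, within the scatter of two such steps Putting hydrogen in place of fluoro gives a 1.5-fold lower number from compound 2 to compound 4 (0.18 log units; within the scatter), and this also agrees with its earlier step: the same change on two cores in this assay, no change at the digits printed (within the scatter) from compound 1 to compound 3 and a 1.5-fold lower number (0.18 log units; within the scatter) from compound 2 to compound 4, 1.5-fold (0.18 log units) apart, within the scatter of two such steps Each change therefore carried from one core to the other without a difference beyond the scatter, but this is a weak test: no step here is large enough to show that a real effect on this number transfers between cores, so the result shows only that both changes stay small on both cores in these four compounds.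

The compounds shown leave open whether a change that moves this number beyond the scatter would carry across cores in the same way, for example a chloro or methoxy group in place of the fluoro, or an amine or a carboxylic acid attached to the group on the ring nitrogen. They also leave open whether the same agreement would hold in a read-out other than this one.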